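The source may report more compounds than this note shows. Statements on the series, on what has been measured and on what is new or still open speak of the compounds shown alone.

Notes on the series, step from compound 3 to compound 4.

Among the compounds with values here, compound 3 `CCC(F)(F)C(=O)N1CCC(Oc2ncnc(Oc3ccc(S(C)(=O)=O)nc3C)c2F)CC1` sits at the top of the three numbers measured so far: in a functional assay on isolated protein for inhibition of Glucose-dependent insulinotropic receptor (Rattus norvegicus), read by HTRF and cAMP accumulation (a higher number here means a larger maximal response, a lower number a smaller maximal response), compound 3 gives 90%. Compound 1 `CCC1(OC(=O)N2CCC(Oc3ncnc(Oc4ccc(S(C)(=O)=O)nc4C)c3F)CC2)CC1` is nearest, with 83% in this assay, and the gap a number 7 percentage points higher from compound 1 to compound 3 (within the scatter). Compound 2 `Cc1nc(S(C)(=O)=O)ccc1Oc1ncnc(OC2CCN(C(=S)OC3(C)CC3)CC2)c1F` is furthest; in this assay compound 2 gives 49%, and the gap a number 41 percentage points higher from compound 2 to compound 3 (beyond the scatter).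

Compound 4 `Cc1nc(S(C)(=O)=O)ccc1Oc1ncnc(OC2CCN(C(=O)c3nc(C(C)(C)F)no3)CC2)c1F` is not yet measured in this assay. Relative to compound 3 the change is a group of 9 heavy atoms (5 carbon, 2 nitrogen, 1 oxygen, 1 fluorine; one five-membered aromatic ring with 3 hetero atoms) in place of a group of 5 heavy atoms (3 carbon, 2 fluorine; no ring), on a carbonyl carbon.

Of the measured steps, the one that bears most directly on this change is the one at the same position, the carbonyl carbon: a number 7 percentage points higher from compound 1 to compound 3 (within the scatter). The two large steps, a number 34 percentage points lower from compound 1 to compound 2 (beyond the scatter) and a number 41 percentage points higher from compound 2 to compound 3 (beyond the scatter), concern the group on the amine nitrogen in the ring and thus a different place, and they show the series can move by large amounts. Given the single carbonyl-carbon step stayed within the scatter, no step beyond the scatter is expected here, though the entering five-membered aromatic ring with 3 hetero atoms is larger than anything tried at this position, so the range is kept wide. For compound 4 the step from compound 3 is expected to be a number 8 percentage points lower from compound 3 to compound 4 (within the scatter). For compound 4 the estimate in this assay is 82%, with a range from 55% to 100%.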

Compound 4, largest response reached (reported as efficacy), in percent of the reference or control that the assay uses: 84%
Estimate against measurement, compound 4: 2 percentage points below, and the stated range covers the measured number.
By their numbers in this assay, from the lowest: compound 2; then compounds 1, 4 and 3 (each within the scatter of the next).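

In this assay the carbonyl carbon accepts a larger group carrying a five-membered aromatic ring with 3 hetero atoms and hydrogen-bond acceptors, where 1,1-difluoropropyl has none, and the step is only a number 6 percentage points lower from compound 3 to compound 4 (within the scatter). Within the data shown here, the step of a number 1 percentage points higher from compound 1 to compound 4 (within the scatter) also stays within the scatter, so the groups on the carbonyl carbon in compounds 1, 3 and 4 are not separated by this read-out, while the step of a number 35 percentage points higher from compound 2 to compound 4 (beyond the scatter) leaves the sulfur-containing compound 2 as the one compound apart from the others. Nothing measured here bears on why these three numbers stay together.

Still open is how an amine or a carboxylic acid at the carbonyl carbon would read in this assay, since the groups shown there carry neither. Also open, as far as these compounds go, is whether the fluorine in the entering group counts for anything, which a comparison with an isopropyl group in its place on the same five-membered ring would address.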